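Swapping a phenyl for a pyrazole on a full agonist

This account rests on a few compounds, and the source may have more. Where it says the series, first, only, none or still open, it means among the compounds named here.

Compound 2 `COc1ccc(N2C[C@@H](C)N[C@@H](C)C2)cc1NS(=O)(=O)c1ccc(-c2ccccc2)cc1` is one of two measured compounds. In a functional assay for agonist activity at growth hormone secretagogue receptor type 1 (Homo sapiens), read by FLIPR (a higher number here means a larger maximal response, a lower number a smaller maximal response), compound 2 gives 1. Compound 1 `C[C@@H]1CN(c2cc(NS(=O)(=O)c3ccc(-c4ccccn4)s3)ccc2C#N)C[C@H](C)N1` gives 0.9 in this assay, and the two values lie within the usual scatter of each other, so neither stands apart. Compound 3 `COc1ccc(N2C[C@@H](C)N[C@@H](C)C2)cc1NS(=O)(=O)c1ccc(-n2cccn2)cc1` has not been measured. It differs from compound 2 in one place: 1H-pyrazol-1-yl in place of phenyl on an aromatic carbon. Nothing measured here shows what this change does, so compound 3 is expected to stay close to compound 2, with a step of a number 0.10 lower from compound 2 to compound 3 (within the scatter) that should lie within the scatter. Compound 3 is estimated at 0.9, with a range from 0.6 to 1.05.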

Compound 3, intrinsic activity: the largest response reached, as a fraction of the reference agonist's: 0.8
Compound 3: the middle estimate sits 0.10 above what was measured; measured number inside the range.
By their numbers in this assay, from the lowest: compounds 3, 1 and 2 (each within the scatter of the next, the first and the last beyond it).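

Swapping phenyl for 1H-pyrazol-1-yl on this aromatic carbon, para to a large group, gives a number 0.20 lower from compound 2 to compound 3 (beyond the scatter) in this assay and this modest step shows that the group at this position does influence the maximal response. Even so, the change leaves a sizeable response in place. Nothing available explains the drop.

As far as these compounds go, it remains open whether other groups at this position, such as an imidazole ring, an amine or a carboxylic acid, would keep the response of compound 2 or lower it further.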